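Chloro in Place of Hydrogen on the Phenoxy Group

This account rests on a few compounds, and the source may have more. Where it says the series, first, only, none or still open, it means among the compounds named here.

Compound 1, `NC1=NC2(CCOCC2)N(OCCCOc2ccccc2)C(N)=N1`, was examined in an assay on isolated protein for inhibition of Dihydrofolate reductase (Homo sapiens), read by spectrophotometry, using NADPH, with stated times of 5 s and 6 min, tested at 5 uM; on this read-out higher numbers stand for a stronger effect at the one concentration tested and lower numbers for a weaker effect. In this assay compound 1 gives > 90%, which is a limit of the assay rather than a number. Compound 2, `NC1=NC2(CCSCC2)N(OCCCOc2ccc(Br)cc2)C(N)=N1`, was tested in the same way. In this assay compound 2 gives > 90%, again a limit and not a number. Both values shown therefore sit at the limit of > 90% in this assay, at which 2 of the 2 values shown sit, and compound 1 stands at that limit with no measured number to set against it. Within the data shown here, no step between measured compounds is available. Compound 3, `NC1=NC2(CCOCC2)N(OCCCOc2ccccc2Cl)C(N)=N1`, has not yet been measured. It differs from compound 1 by chloro in place of hydrogen on an aromatic carbon. Given that both values shown sit at the limit of > 90% in this assay, at which 2 of the 2 values shown sit, the step that the limit leaves unreadable from compound 1 to compound 3 is expected to be none beyond the scatter. Compound 3 is expected to give 92%, with a range from 80% to 100%, most likely reported once more as a limit rather than a number.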

Compound 3, a percentage reported as inhibition, at one concentration (the size of the read-out at that concentration, not a potency): 83.3%
Beside the measured number, compound 3's estimate is 8.7 percentage points above it, within the range that was stated.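

Compound 3 is the first of the compounds shown to carry a number rather than a limit: in this assay compound 3 gives 83.3%. Among these compounds, with chloro in place of hydrogen on an aromatic carbon, ortho to a large group, the read-out shows a number at least 6.7 percentage points lower from compound 1 to compound 3 (that floor lies within the scatter), so this change gives no step that can be told from the scatter. The true size of the step stays unknown because compound 1 has only a limit and no number: the limit of > 90% in this assay, at which 2 of the 3 values shown sit.

The compounds shown leave open how an amine, a methoxy group or a carboxylic acid in place of chloro would read at this position. They also leave open whether a shorter or longer chain to the phenoxy group would alter the read-out.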